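From 2-Phenylphenyl to 4-Bromophenyl in a Cytotoxicity Screen

A few compounds are considered here, and "the series" means these few. Any claim that something is new, unique, unknown or untested is made for them only; others in the source may bear on it.

Measured compounds:
compound 1 `COC(=O)c1ccc(NCc2cncn2Cc2ccccc2-c2ccccc2)cc1-c1ccccc1` — "not determined" (no result reported)
compound 2 `c1ccc(Cn2cncc2CNc2cccc(-c3ccncc3)c2)cc1` — > 1000 nM
compound 3 `c1ccc(-c2ccc(Cn3cncc3CNc3ccc(-c4cncs4)c(-c4ccccc4)c3)cc2)cc1` — > 1000 nM

In a toxicity assay on NIH3T3 cells (Mus musculus) for cytotoxicity, read by resazurin assay (on this read-out lower numbers stand for an effect already at smaller amounts and higher numbers for an effect only at larger amounts of compound), compound 1 has no result of its own; its entry reads "not determined" (no result reported). Compound 2 gives > 1000 nM, which is a limit of the assay, not a number. Compound 3 likewise gives > 1000 nM, again a limit. Among the values shown there is thus (the limit of > 1000 nM in this assay, at which 2 of the 3 values shown sit), and compound 1 stands without a number beside them. Compound 4 `COC(=O)c1ccc(NCc2cncn2Cc2ccc(Br)cc2)cc1-c1ccccc1` differs from compound 1 in one respect: 4-bromophenyl in place of 2-phenylphenyl on a saturated chain carbon bound to an aromatic nitrogen. Within the data shown here, no measured step exists between any two compounds here, so the size of the step in this assay from compound 1 to compound 4 cannot be read from data; no shift beyond the scatter is expected. Compound 4 is expected to reach only the limit as well, estimated at 1500 nM within 500 nM to 5000 nM.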

Compound 4, half-maximal effective concentration: > 10000 nM
Compound 4: a limit, no number; the forecaster's own chance of this, stated with the estimate: 75%; middle value at least 6.6-fold (0.82 log units) from the limit.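

Compound 4 gives > 10000 nM here, which is a limit and not a number. Among these compounds, compound 1 has no number either, so no step from compound 1 to compound 4 can be read. The compounds shown leave open how much replacing 2-phenylphenyl with 4-bromophenyl changes cytotoxicity.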